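The compounds below may be only part of what the source reports. "The series", "measured", "known", "first", "only" and "open" are said of these compounds alone.

Compound 2 `Clc1ccccc1-c1nnc2nnc(N3CCCC3)nn12` gives 29600 nM in a functional assay on MCF7 cells (Homo sapiens) for cytotoxicity, read by MTT assay, with a stated time of 72 h; on this read-out lower numbers stand for stronger inhibition and higher numbers for weaker inhibition. Going by the values given here, it carries the lowest of the three numbers measured so far, though this position is only nominal: compound 1 `Cc1nnc2nnc(N3CCCC3)nn12` gives 44800 nM, compound 3 `CC(C)c1nnc2nnc(N3CCCC3)nn12` gives 46800 nM, and all three values sit within the usual scatter of one another. The measured steps confirm this; a 1.5-fold lower number from compound 1 to compound 2 (0.18 log units; within the scatter), a 1.0-fold higher number from compound 1 to compound 3 (0.02 log units; within the scatter) and a 1.6-fold higher number from compound 2 to compound 3 (0.20 log units; within the scatter) all stay within the scatter, so the exchange of methyl, isopropyl and 2-chlorophenyl on the aromatic carbon of the shared core has not moved this assay in any direction.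

Compound 4 `Clc1ccc(-c2nnc3nnc(N4CCCC4)nn23)c(Cl)c1` differs from compound 2 by chloro in place of hydrogen on an aromatic carbon. Among the compounds with values here, none of the measured steps touches this place on the six-membered ring; they concern only what sits on the aromatic carbon of the core. Within the data shown here, the series therefore offers no direct precedent, only the general observation that the three substituent swaps made so far leave this assay unchanged. On that basis no step beyond the scatter is expected, and the number for compound 4 is expected to be 25000 nM, between 9000 nM and 70000 nM, corresponding to an expected step of a 1.2-fold lower number from compound 2 to compound 4 (0.07 log units; within the scatter).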

Compound 4, half-maximal inhibitory concentration: 19600 nM
Compound 4: the middle estimate sits 1.3-fold (0.11 log units) above what was measured; low and high end bracket the measured number.
By their numbers in this assay, from the lowest: compounds 4, 2, 1 and 3 (each within the scatter of the next, the first and the last beyond it).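

In this assay, chloro in place of hydrogen, on the six-membered aromatic ring of carbon only, meta to a chloro group and para to a large group, gives a 1.5-fold lower number from compound 2 to compound 4 (0.18 log units; within the scatter) and so stays with the earlier swaps. Going by these compounds alone, this is the first step made on that ring itself rather than on the aromatic carbon of the shared core, and it shows that this place takes a chloro group without a reading beyond the scatter. No measurement bearing on this step is available to interpret it further.

On these data alone, whether this place remains as flat with a different kind of group, such as methoxy, an amine or a carboxylic acid, stays open, and so does whether any group there can produce a step beyond the scatter from compound 2. Also open is whether chloro at this place would read the same with hydrogen in place of the existing chloro group on the ring, as the compounds shown give this place only on a ring that already carries one.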